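Compound 3 and its phenyl counterpart, compound 4

The compounds below may be only part of what the source reports. "The series", "measured", "known", "first", "only" and "open" are said of these compounds alone.

In a functional assay on CWR22R cells (Homo sapiens) for inhibition (a higher number here means a weaker inhibitor, a lower number a stronger inhibitor), compound 1 `CCn1c(=O)/c(=C2\Sc3cc(F)ccc3N2C)s/c1=C\c1ccncc1Nc1ccccc1Cl` gives 490 nM.
In this assay compound 2 `CCn1c(=O)/c(=C2\Sc3ccccc3N2C)s/c1=C\c1ccncc1Nc1ccccc1F` gives 300 nM.
In this assay compound 3 `c1ccc(Nc2nc(-c3nc4ccccc4s3)cs2)nc1` gives 3200 nM.

Compound 3 stands with the highest number of the three, and its distance from both compound 1 and compound 2 lies beyond the usual scatter, so it is the weakest inhibitor of this set. Compound 4 `c1ccc(Nc2nc(-c3nc4ccccc4s3)cs2)cc1` is not yet measured. It differs from compound 3 in one place: phenyl in place of pyridin-2-yl on a nitrogen on an aromatic ring. Within the data shown here, no measured pair in this set shows that change, so its effect is unknown here. The shared core is kept, and only the ring on the nitrogen changes, so a small step, likely within the scatter, is expected in this assay for the move a 1.3-fold higher number from compound 3 to compound 4 (0.10 log units; within the scatter). For compound 4 a value of about 4000 nM is estimated, most plausibly between 1500 nM and 11000 nM.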

Compound 4, half-maximal inhibitory concentration: 6900 nM
Estimate against measurement, compound 4: 1.7-fold (0.24 log units) below; measured number inside the range.
By their numbers in this assay, from the lowest: compounds 2 and 1 (each within the scatter of the next); then compound 3; then compound 4.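

In this assay, among these compounds, phenyl in place of pyridin-2-yl on a nitrogen on an aromatic ring gives a 2.2-fold higher number from compound 3 to compound 4 (0.33 log units; beyond the scatter), the first reading of a single change in this set. At this position, pyridin-2-yl therefore gives the stronger inhibitor of the pair, by a modest step. Nothing measured here accounts for the difference.

The compounds shown leave open how pyridin-3-yl or pyrimidin-2-yl would compare at this position. They also leave open what an amine or a carboxylic acid on this ring would do.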